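Ethyl for methoxy on the core of compound 1

The source may report more compounds than this note shows. Statements on the series, on what has been measured and on what is new or still open speak of the compounds shown alone.

Measured so far:
compound 1, `COCc1nc(C)c2c(C)nnc(O)n12`, > 48000 nM
compound 2, `Oc1nnc(Br)c2c(Br)nc(Br)n12`, 27000 nM
compound 3, `CSc1nncc2c(C)nc(C)n12`, > 48000 nM

Three compounds have been run in a functional assay for inhibition, with Homo sapiens as the target; on this read-out higher numbers stand for weaker inhibition and lower numbers for stronger inhibition. Compound 1 gives > 48000 nM there, which is a limit of the assay and not a number. Compound 3 likewise gives > 48000 nM in this assay, again a limit. Going by the values given here, compound 2 gives 27000 nM in this assay, the only numeric value of the three. Among the compounds with values here, compound 1 therefore stands at the ceiling of what this assay reports, the situation described by the limit of > 48000 nM in this assay, at which 2 of the 3 values shown sit, and no step between measured compounds that differ in one place can be read from the set.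

Compound 4 (`CCCc1nc(C)c2c(C)nnc(O)n12`) is not yet measured. It differs from compound 1 by ethyl in place of methoxy on a saturated chain carbon bound to an aromatic carbon; cut one bond further out, the same difference reads methoxymethyl to propyl. Within the data shown here, with compound 1 at a limit, no measured step anchors the size of the change expected in this assay; the expectation from compound 1 to compound 4 is a step that the limit leaves unreadable from compound 1 to compound 4, none beyond the scatter, in either direction. Compound 4 is expected at 60000 nM, in the range 20000 nM to 150000 nM, most likely reported as a limit again.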

Compound 4, half-maximal inhibitory concentration: 14000 nM
The estimate for compound 4 lay 4.3-fold (0.63 log units) above the measured number; measured number below the stated range.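

In this assay, going by these compounds alone, ethyl in place of methoxy on a saturated chain carbon bound to an aromatic carbon gives an at least 3.4-fold lower number from compound 1 to compound 4 (0.53 log units; beyond the scatter), the first step that can be read at all. This position therefore responds to the change from methoxymethyl to propyl, and compound 4, at 14000 nM, gives the shared core a numeric value with the other groups on it unchanged from compound 1. The step gives only a lower bound on the size of the change, because compound 1 stands at a limit and not at a number: the limit of > 48000 nM in this assay, at which 2 of the 4 values shown sit.

As far as these compounds go, the true size of the step remains open, as does whether the chain carbon count or the loss of the methoxy oxygen accounts for it, since this single pair changes both at once. Also open, from the compounds shown here alone, is how a longer chain such as butyl, or an amine or carboxylic acid at the end of the chain, would move the number in this assay, and whether the step carries over to other substitution on the core, given that compound 2 and compound 3 differ from compound 1 in more than one place.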